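The source may hold more compounds than are shown below. What is called first, only, known or untested is meant among the compounds shown, and "the series" means these compounds.

For the measured compounds named here, compound 1 `N#Cc1c(N)nc(SCC(N)=O)c(C#N)c1-c1ccc(OCC2CC2)cc1` gives 8% in an assay on CHO cells for displacement of a labelled ligand from adenosine receptor A3 (Homo sapiens), read by scintillation counting, with a stated time of 120 min, tested at 1 uM (a lower number here means less inhibition, a higher number more inhibition at the concentration tested (going by the name of the read-out)), and stands second highest of the three numbers measured so far: compound 2 `N#Cc1c(N)nc(SCc2cccnc2)c(C#N)c1-c1ccc(OCC2CC2)cc1` gives 19% and compound 3 `N#Cc1c(N)nc(SCc2nc3ccccc3[nH]2)c(C#N)c1-c1ccc(OCC2CC2)cc1` gives 1%. The step of a number 11 percentage points higher from compound 1 to compound 2 (beyond the scatter) and the step of a number 7 percentage points lower from compound 1 to compound 3 (within the scatter) both alter the group on the saturated chain carbon bound to a sulfur. Compound 4 `C=C(C)COc1ccc(-c2c(C#N)c(N)nc(SCC(N)=O)c2C#N)cc1` differs from compound 1 at a different place: 1-methylethenyl in place of cyclopropyl on a saturated chain carbon bound to an oxygen on an aromatic ring. Going by the values given here, no measured step touches this part of the shared core, so there is nothing to set a size or direction for the change, and the expected step is none beyond the scatter. Compound 4 is therefore expected to give 8% in this assay, between -4% and 20%. That expected step is no change at the digits printed from compound 1 to compound 4 (within the scatter).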

Compound 4, a percentage reported as inhibition, at one concentration (the size of the read-out at that concentration, not a potency): 4%
Beside the measured number, compound 4's estimate is 4 percentage points above it; low and high end bracket the measured number.
By their numbers in this assay, from the lowest: compounds 3, 4 and 1 (each within the scatter of the next); then compound 2.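

For the compounds shown here, until now no step had touched the saturated chain carbon bound to an oxygen on an aromatic ring. Here, in this assay, 1-methylethenyl in place of cyclopropyl, with three carbons on each side, gives a number 4 percentage points lower from compound 1 to compound 4 (within the scatter), so losing the three-membered ring leaves no reading beyond the scatter, though only with carbamoyl at the other varied place. Nothing available explains this result.

On these data alone, whether a longer chain or an amine here would move the number stays open. So does whether this change would read the same with pyridin-3-yl in place of carbamoyl.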